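The compounds below may be only part of what the source reports. "The series", "measured", "known", "first", "only" and "open" are said of these compounds alone.

In a functional assay on DU-145 cells (Homo sapiens) for inhibition, read by trypan blue exclusion, with a stated time of 96 h (a higher number here means a weaker inhibitor of growth, a lower number a stronger inhibitor of growth), compound 1 (`Cc1cc(C)cc(/C=C(/SCc2ccc(F)cc2)C(=O)c2ccc(Br)cc2)c1`) gives 10000 nM and compound 2 (`COc1ccc(/C=C(/SCc2ccc(Cl)cc2)C(=O)c2ccc(Br)cc2)cc1O`) gives 1000 nM as the lower of the two numbers, a gap beyond the scatter. Compound 3 (`Cc1ccc(S(=O)(=O)/C(=C/c2c(F)c(F)c(F)c(F)c2F)C(=O)c2ccc(Cl)cc2)cc1`) has only a limit (> 100000 nM) and no number. Compound 4 (`O=C(/C(=C\c1cc(Cl)cc(Cl)c1Cl)SCc1ccc(Cl)cc1)c1ccc(Br)cc1`) differs from compound 2 in one place: 2,3,5-trichlorophenyl in place of 3-hydroxy-4-methoxyphenyl on a double-bonded chain carbon bound to a double-bonded chain carbon puts 2,3,5-trichlorophenyl in place of 3-hydroxy-4-methoxyphenyl. Going by the values given here, no measured pair isolates this change. Compound 1 (10000 nM) also lacks the 3-hydroxy-4-methoxyphenyl group, though it differs from compound 2 elsewhere too, so a move to a higher number is expected, probably beyond the scatter. In this assay the expected change is a 5.0-fold higher number from compound 2 to compound 4 (0.70 log units; beyond the scatter) as an estimate. Compound 4 is estimated at 5000 nM (expected range 1200 nM to 25000 nM).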

Compound 4, concentration for 50% growth inhibition: 1000 nM
Compound 4: the middle estimate sits 5.0-fold (0.70 log units) above what was measured; the measured number lies below the stated range.
By their numbers in this assay, from the lowest: compounds 2 and 4 (each within the scatter of the next); then compound 1. At a limit, above all of these: compound 3.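

In this assay, putting 2,3,5-trichlorophenyl in place of 3-hydroxy-4-methoxyphenyl gives no change at the digits printed from compound 2 to compound 4 (within the scatter). This place on the chain therefore accepts a group with no hydrogen-bond donors and no hydrogen-bond acceptors, and the hydroxy and methoxy groups are not needed to hold the number in this assay. The data shown offer no explanation for this result. As far as these compounds go, whether an amine or a carboxylic acid at this place would give a similar number remains open. So does whether the same exchange behaves alike when the other parts of the core differ.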